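The compounds below may be only part of what the source reports. "The series", "measured", "known", "first", "only" and "open" are said of these compounds alone.

Compound 1 `COc1cc(/C=C/C(=O)C(=Cc2ccccc2)C(=O)/C=C/c2ccc(O)c(OC)c2)ccc1O` – "not determined" (no result reported)
Compound 2 `COc1cc(/C=C/C(=O)C(=Cc2ccc(N(C)C)cc2)C(=O)/C=C/c2ccc(O)c(OC)c2)ccc1O` – > 100000000 nM

In an ADME assay on L123 cells (Homo sapiens) for cytotoxicity, read by MTT assay, with a stated time of 48 h (on this read-out lower numbers stand for stronger inhibition and higher numbers for weaker inhibition), compound 2 reaches only the limit > 100000000 nM and no actual number. The move to compound 3 `COc1cc(/C=C/C(=O)C(=Cc2ccccc2O)C(=O)/C=C/c2ccc(O)c(OC)c2)ccc1O` is 2-hydroxyphenyl in place of 4-(dimethylamino)phenyl on a double-bonded chain carbon bound to a double-bonded chain carbon and puts 2-hydroxyphenyl in place of 4-(dimethylamino)phenyl on a double-bonded chain carbon bound to a double-bonded chain carbon. For the measured compounds named here, no measured step exists to guide the expectation here. The estimated change is an at least 2.5-fold lower number from compound 2 to compound 3 (0.39 log units; beyond the scatter) toward stronger inhibition, a modest move, and another limit would be no surprise. For compound 3 the expected value is 40000000 nM within an estimated range of 4000000 nM to 100000000 nM in this assay once tested.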

Compound 3, half-maximal inhibitory concentration: 50000000 nM
Estimate against measurement, compound 3: 1.3-fold (0.10 log units) below; low and high end bracket the measured number.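

In this assay, for the compounds shown here, compound 3, with 2-hydroxyphenyl at this position, gives 50000000 nM, the first actual number for a group on a double-bonded chain carbon bound to a double-bonded chain carbon. Compound 2 holds only a limit of the assay: the limit of > 100000000 nM in this assay, at which 1 of the 3 values shown sits.
From the compounds shown here alone, the change can thus be read only as a floor, an at least 2.0-fold lower number from compound 2 to compound 3 (0.30 log units; that floor lies within the scatter), and its true size stays unknown.

Still open, going by these compounds, is how 4-hydroxyphenyl or 2-aminophenyl would read at this position. Also open, on these data alone, is how much of the step comes from gaining the hydroxyl and how much from losing the dimethylamino group.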